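Adding ((allyloxycarbonyl)amino)methyl to the shared core

This account rests on a few compounds, and the source may have more. Where it says the series, first, only, none or still open, it means among the compounds named here.

In a functional assay on A549 cells (Homo sapiens) for cytotoxicity, read by resazurin assay, with a stated time of 48 h (a higher number here means a weaker inhibitor, a lower number a stronger inhibitor), compound 1 (`C=C(C)[C@@H]1CC=C(CN(OC)C2O[C@H](CO)[C@@H](N=[N+]=[N-])[C@H](O)[C@H]2O)CC1`) gives 4000 nM and compound 2 (`C=C(C)[C@@H]1CC=C(CN(OC)C2O[C@H](CO)[C@@H](O)[C@H](NC(=O)CCCCCCCCC)[C@H]2O)CC1`) reads 14000 nM in the same test. Compound 3 (`C=C(C)[C@@H]1CC=C(CN(OC)C2OC[C@@H](O)[C@H](O)[C@H]2O)CC1`) stands at 202000 nM as the highest of the three numbers, beyond the scatter from both others. Compound 4 (`C=CCOC(=O)NC[C@H]1OC(N(CC2=CC[C@@H](C(=C)C)CC2)OC)[C@H](O)[C@@H](O)[C@@H]1O`) has ((allyloxycarbonyl)amino)methyl in place of hydrogen on a saturated ring carbon, next to the ring oxygen (((allyloxycarbonyl)amino)methyl in place of hydrogen on a saturated ring carbon). For the measured compounds named here, no measured pair isolates this change. Compound 3 carries the least on the core, while compound 2 reaches 14000 nM with more attached, so a lower number is expected, beyond the scatter. The expected step is a 6.7-fold lower number from compound 3 to compound 4 (0.83 log units; beyond the scatter) in this test. For compound 4 the estimated value is 30000 nM within an expected range of 8000 nM to 100000 nM in this assay.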

Compound 4, half-maximal inhibitory concentration: 140000 nM
Beside the measured number, compound 4's estimate is 4.7-fold (0.67 log units) below it; the measured number lies above the stated range.
By their numbers in this assay, from the lowest: compound 1; then compound 2; then compounds 4 and 3 (each within the scatter of the next).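

In this assay, ((allyloxycarbonyl)amino)methyl in place of hydrogen on a saturated ring carbon, next to the ring oxygen, gives a 1.4-fold lower number from compound 3 to compound 4 (0.16 log units; within the scatter) and so leaves the reading where hydrogen had it. For the compounds shown here, this position therefore takes an addition of 8 heavy atoms without a reading that stands apart from compound 3, which the earlier compounds could not show. Nothing available explains this result. From the compounds shown here alone, whether an aminomethyl group or a carboxylic acid at this position would read differently remains open. So does whether ((allyloxycarbonyl)amino)methyl would read the same on the core of compound 1.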